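Adding a Fourth Methoxy to a Weakly Cytotoxic Ketone

The source may hold more compounds than are shown below. What is called first, only, known or untested is meant among the compounds shown, and "the series" means these compounds.

Compound 1, `COc1cc(C2CCc3cc(OC)c(OC)c(OC)c32)cc(OC)c1OC`: in a functional assay on WRL68 cells (Homo sapiens) for cytotoxicity, read by MTT assay, with a stated time of 24 h (a higher number here means a weaker inhibitor, a lower number a stronger inhibitor), compound 1 gives 154000 nM.
Compound 2, `COc1cc2c(cc1OC)C(c1cc(OC)c(OC)c(OC)c1)CC2=O`: compound 2 gives 196000 nM.
Compound 3, `COc1cc2c(c(OC)c1OC)C(c1ccccc1)CC2=O`: compound 3 gives >= 250000 nM, which is a limit of the assay and not a number.

All three compounds share a core carrying several methoxy groups, and none is a strong inhibitor in this assay. The numbers for compound 2 and compound 1 lie within the scatter of each other, so the two cannot be told apart. The third value sits at the limit of >= 250000 nM in this assay, at which 1 of the 3 values shown sits.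

Compound 4, `COc1cc(C2CC(=O)c3cc(OC)c(OC)c(OC)c32)cc(OC)c1OC`, differs from compound 2 by methoxy in place of hydrogen on an aromatic carbon. Within the data shown here, no measured pair shows what this particular change does here, and the three values already in hand are close together or at the limit. The expectation is therefore a step of no more than the scatter, in no clear direction. Compound 4 is estimated at 180000 nM, expected to fall between 90000 nM and 260000 nM. The expected step of a 1.1-fold lower number from compound 2 to compound 4 (0.04 log units; within the scatter) is small.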

Compound 4, half-maximal inhibitory concentration: 12800 nM
Estimate against measurement, compound 4: 14-fold (1.15 log units) above; measured number outside the range, below it.
By their numbers in this assay, from the lowest: compound 4; then compounds 1 and 2 (each within the scatter of the next). At a limit, above all of these: compound 3.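

In this assay, adding a further methoxy group where a hydrogen stood, ortho to a fused ring and ortho to a methoxy group, gives a 15-fold lower number from compound 2 to compound 4 (1.19 log units; beyond the scatter). The earlier compounds shown here had values close together or at a limit, and gave no sign that one small change to the shared core could matter this much, but this position clearly responds to what sits on it. The data shown offer no measured explanation for why the step is so large.

Among the compounds shown, this position carries only hydrogen or methoxy, so it remains open whether a hydroxyl, a fluorine or an amine there would have a similar effect. A single pair also leaves open whether the same change would give a similar step on a different core.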